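The source may report more compounds than this note shows. Statements on the series, on what has been measured and on what is new or still open speak of the compounds shown alone.

Measured so far in a functional assay for antagonist activity, with Cavia porcellus as the target; a lower number here means a stronger inhibitor, a higher number a weaker inhibitor:
- compound 1 `CCCCCCSC[C@H]1C2CC[C@@H](O2)[C@H]1C/C=C\CCCC(=O)O`: 500 nM 
- compound 2 `CCC/C=C/CSCC1C2CCC(O2)C1C/C=C\CCCC(=O)O`: 400 nM 

The values of compound 1 and compound 2 lie within the scatter of each other, so these two numbers show no separation and compound 2 stands level with compound 1 on the data available.

Compound 3 `CCC/C=C\CSCC1C2CCC(O2)C1C/C=C\CCCC(=O)O` has not been measured. Its relation to compound 2 is this: the two compounds have the same atoms and bonds; at least one stereo element is drawn with a configuration in one of them and without one in the other: 1 of 6 stereo elements differ; a double bond is drawn E in compound 2 and Z in compound 3; a double bond is drawn E in compound 2 and Z in compound 3. Among the measured compounds shown here, no measured pair shows what such a change does. For the measured compounds named here, the only guides are compound 2 at 400 nM and compound 1 at 500 nM, so no change beyond the scatter is expected in this assay, in either direction. The estimated no change at the digits printed from compound 2 to compound 3 (within the scatter) is expected to stay within that scatter. Compound 3 is expected at 400 nM, with an estimated range from 150 nM to 1100 nM for the measurement.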

Compound 3, half-maximal inhibitory concentration: 1600 nM
Beside the measured number, compound 3's estimate is 4.0-fold (0.60 log units) below it; measured number outside the range, above it.
By their numbers in this assay, from the lowest: compounds 2 and 1 (each within the scatter of the next); then compound 3.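

In this assay, turning one double bond from E to Z, with atoms and bonds unchanged, gives a 4.0-fold higher number from compound 2 to compound 3 (0.60 log units; beyond the scatter). Among the compounds shown here, this is the first separation beyond the scatter, and it marks the geometry of this double bond as something the read-out responds to, which the earlier compounds, level with each other, could not show. The step still cannot be taken as a clean effect of E against Z alone, and one caution applies to it: the fact that one of compounds 2 and 3 is drawn with a defined configuration and the other without, at the place where they differ

As far as these compounds go, whether the same sensitivity holds with a longer chain or a phenyl group in place of the chain carrying this double bond remains open. Also open, from the compounds shown here alone, is whether a fully defined configuration at every stereo element would leave the step at this size.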